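Phenyl to phenyltetrazolyl on the chain carbon

The compounds below may be only part of what the source reports. "The series", "measured", "known", "first", "only" and "open" are said of these compounds alone.

Compound 2 `CCC(C)n1ncn(-c2ccc(N3CCN(c4ccc(OC[C@@H]5CO[C@@](Cc6ccccc6)(c6ccc(Cl)cc6Cl)O5)cc4)CC3)cc2)c1=O` gives 513 nM in a functional assay on HUVEC cells (Homo sapiens), read by scintillation counting and thymidine incorporation, with a stated time of 24 h; a lower number here means a stronger inhibitor, a higher number a weaker inhibitor. Among the three compounds measured so far it holds the second highest number: compound 1 `CCC(C)n1ncn(-c2ccc(N3CCN(c4ccc(OC[C@@H]5CO[C@@](CC)(c6ccc(Cl)cc6Cl)O5)cc4)CC3)cc2)c1=O` gives 353 nM, and compound 3 `CCC(C)n1ncn(-c2ccc(N3CCN(c4ccc(OC[C@@H]5CO[C@@](Cn6c(C)cnc6C)(c6ccc(Cl)cc6Cl)O5)cc4)CC3)cc2)c1=O` gives 765 nM. Both neighbours lie within the scatter of compound 2 (a 1.5-fold higher number from compound 1 to compound 2 (0.16 log units; within the scatter); a 1.5-fold higher number from compound 2 to compound 3 (0.17 log units; within the scatter)), so no order among the three can be drawn from these numbers.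

Compound 4 `CCC(C)n1ncn(-c2ccc(N3CCN(c4ccc(OC[C@@H]5CO[C@@](Cn6nnnc6-c6ccccc6)(c6ccc(Cl)cc6Cl)O5)cc4)CC3)cc2)c1=O` has not yet been measured. It differs from compound 2 in one place: 5-phenyl-1H-tetrazol-1-yl in place of phenyl on a saturated chain carbon bound to a saturated ring carbon.

The step that bears most directly on this change is a 1.5-fold higher number from compound 2 to compound 3 (0.17 log units; within the scatter), where 2,5-dimethyl-1H-imidazol-1-yl took the place of phenyl on the same saturated chain carbon and the number stayed within the scatter. The related step of a 2.2-fold higher number from compound 1 to compound 3 (0.34 log units; beyond the scatter), methyl to the same azole, was modest. On this basis a second azole at the same position, here carrying a phenyl, is expected to leave the number about where compound 2 sits or to raise it modestly, an expected step of a 1.5-fold higher number from compound 2 to compound 4 (0.16 log units; within the scatter), and a clear drop in number is not expected.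

The estimate for compound 4 in this assay is 750 nM, with a range from 350 nM to 1600 nM.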

Compound 4, half-maximal inhibitory concentration: 119 nM
Beside the measured number, compound 4's estimate is 6.3-fold (0.80 log units) above it; measured number below the stated range.
By their numbers in this assay, from the lowest: compound 4; then compounds 1, 2 and 3 (each within the scatter of the next, the first and the last beyond it).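

In this assay, the place on a saturated chain carbon bound to a saturated ring carbon now shows a step to a lower number beyond the scatter, a 4.3-fold lower number from compound 2 to compound 4 (0.63 log units; beyond the scatter), and compound 4 also sits clearly lower against the methyl and azole groups, with a 3.0-fold lower number from compound 1 to compound 4 (0.47 log units; beyond the scatter) and a 6.4-fold lower number from compound 3 to compound 4 (0.81 log units; beyond the scatter). Compound 4 is thus the strongest inhibitor of the four, and an azole at this place does not set the direction of the step: relative to methyl, a 2.2-fold higher number from compound 1 to compound 3 (0.34 log units; beyond the scatter) runs the opposite way to the step for 5-phenyl-1H-tetrazol-1-yl. No measurement on hand accounts for this difference between the two azoles.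

The compounds shown do not separate the part played by the tetrazole ring from that of the phenyl it carries, and a 5-methyl-1H-tetrazol-1-yl group at the same place would bear directly on that question. On these data alone, how an amine or a carboxylic acid at this chain carbon would read in this assay also remains open.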